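From a Cycloheptyl Ring to a Benzyl Group

The source may report more compounds than this note shows. Statements on the series, on what has been measured and on what is new or still open speak of the compounds shown alone.

In a functional assay on PC-3 cells (Homo sapiens) for cytotoxicity, read by WST assay, with a stated time of 72 h (a higher number here means a weaker inhibitor, a lower number a stronger inhibitor), compound 2 (`O=C1Nc2c(ccc(F)c2F)C1(c1ccc(O)cc1)C1CCCCCC1`) gives 12 nM as the only single number shown. Beside it stands one further entry without a single number, that of compound 1 (`O=C1Nc2c(ccc(F)c2F)C1(c1ccc(O)cc1)C1CCCCC1`). Compound 1 gives 9.2 nM; 32 nM; > 1000 nM (3 entries) across its entries. The last entry of compound 1 is a limit of the assay and not a number.

The next step leads to compound 3 (`O=C1Nc2c(ccc(F)c2F)C1(Cc1ccccc1)c1ccc(O)cc1`), with benzyl in place of cycloheptyl on a saturated ring carbon. Within the data shown here, no measured pair tests this change, so the expectation rests on the structures alone. From the compounds shown here alone, compounds 1 and 2 both carry a saturated ring at this place, and a benzyl group there is untested in this assay, so a modest weakening is expected and not a large one. The estimated change is a 3.3-fold higher number from compound 2 to compound 3 (0.52 log units; beyond the scatter), although the range also allows for no shift beyond the scatter. The range stays wide because the several entries of compound 1 in this assay, 9.2 nM; 32 nM; > 1000 nM (3 entries) disagree with one another. Compound 3 is expected to read 40 nM, within an estimated range of 10 nM to 300 nM for the coming measurement.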

Compound 3, half-maximal inhibitory concentration: > 1000 nM
Compound 3: a limit, no number; the forecaster's own chance of this, stated with the estimate: 12%; middle value at least 25-fold (1.39 log units) away from the limit.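

In this assay, from the compounds shown here alone, the change from cycloheptyl to benzyl is a large one, an at least 83-fold higher number from compound 2 to compound 3 (1.92 log units; beyond the scatter) and its true size stays unknown, as the reading of compound 3 is a limit of the assay and not a number. The two groups match in their count of heavy atoms and differ in their ring, a seven-membered non-aromatic ring of carbon against a six-membered aromatic one, so a matching count alone does not keep the low number of compound 2 at this saturated ring carbon. The contrast still needs care, since compound 1, which also carries a saturated ring at this place, does not read alike across its entries: the several entries of compound 1 in this assay, 9.2 nM; 32 nM; > 1000 nM (3 entries).

The compounds shown leave open which part of benzyl matters, the aromatic ring or the methylene link that joins it to the core. A phenyl group joined directly at this carbon and a cyclohexylmethyl group would pull those two apart, while a cyclopentyl ring would show how far the saturated rings carry.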